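Thiazolyl enones in a gastric cancer cell assay

This account rests on a few compounds, and the source may have more. Where it says the series, first, only, none or still open, it means among the compounds named here.

Measured compounds:
compound 1 `Cc1nc(Nc2ccc(Cl)c(Cl)c2)sc1C(=O)/C=C/c1ccccc1`, 10600 nM
compound 2 `Cc1cccc(Nc2nc(C)c(C(=O)/C=C/c3ccccc3)s2)c1`, 13600 nM
compound 3 `Cc1nc(Nc2ccc(Cl)c(Cl)c2)sc1C(=O)/C=C/c1ccc(Cl)cc1`, 22700 nM

All three were tested in a functional assay on BGC-823 cells (Homo sapiens) for cytotoxicity, read by MTT assay; a higher number here means a weaker inhibitor, a lower number a stronger inhibitor. Compound 4 `Cc1cccc(Nc2nc(C)c(C(=O)/C=C/c3ccc(Cl)cc3)s2)c1` has not yet been measured there. Its core differs from that of compound 1 by chloro in place of hydrogen on an aromatic carbon, a change that gave a 2.1-fold higher number from compound 1 to compound 3 (0.33 log units; beyond the scatter). The change from compound 3 to compound 4 is 3-methylphenyl in place of 3,4-dichlorophenyl on a nitrogen on an aromatic ring, the same change as from compound 1 to compound 2, which gave a 1.3-fold higher number from compound 1 to compound 2 (0.11 log units; within the scatter). Compound 3 already holds the highest number of the three. Within the data shown here, since the earlier step was small, compound 4 is expected to show a step of about a 1.2-fold higher number from compound 3 to compound 4 (0.09 log units; within the scatter), a shift comparable to the one seen between compound 1 and compound 2 in this assay. Compound 4 is thus estimated at 28000 nM, with a likely range from 14000 nM to 56000 nM.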

Compound 4, half-maximal inhibitory concentration: > 25000 nM
Compound 4: a limit, no number (the forecaster's own chance of this, stated with the estimate: 10%); the middle value is on the limit's open side.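

In this assay compound 4 gives > 25000 nM, which is a limit of the assay and not a number. Placing 3-methylphenyl in place of 3,4-dichlorophenyl gives an at least 1.1-fold higher number from compound 3 to compound 4 (0.04 log units; that floor lies within the scatter), which fits the change carrying over from one core to the other but does not prove that its size is kept: the same change on two cores in this assay, a 1.3-fold higher number (0.11 log units; within the scatter) from compound 1 to compound 2 and an at least 1.1-fold higher number (0.04 log units; that floor lies within the scatter) from compound 3 to compound 4; the limit leaves it open whether they differ Chloro in place of hydrogen on an aromatic carbon gives an at least 1.8-fold higher number from compound 2 to compound 4 (0.26 log units; that floor lies within the scatter), so this change also points the same way on both cores, while its size on the second core stays unknown: the same change on two cores in this assay, a 2.1-fold higher number (0.33 log units; beyond the scatter) from compound 1 to compound 3 and an at least 1.8-fold higher number (0.26 log units; that floor lies within the scatter) from compound 2 to compound 4; the limit leaves it open whether they differ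

The compounds shown leave open whether the two changes simply add up on the shared core. They also leave open how an amine or a carboxylic acid in place of the chloro would read in this assay.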